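The source may report more compounds than this note shows. Statements on the series, on what has been measured and on what is new or still open speak of the compounds shown alone.

Compound 1 `C/C=C/C(=O)Nc1cccc(Cn2nc(-c3ccc(Oc4ccccc4)cc3)cc2C(=O)O)c1` and compound 3 `C=CC(=O)Nc1cccc(Cn2nc(-c3ccc(Oc4ccccc4)cc3)cc2C(=O)O)c1` are built on one core, while compound 2 `C/C=C/C(=O)N1CCCC(n2nc(-c3ccc(Oc4ccccc4)cc3)cc2CO)C1` is built on another; how the two cores differ is not broken down here. In a functional assay on Rec1 cells (Homo sapiens) for inhibition, read by luminescence and CellTiter-Glo, with a stated time of 72 h (a lower number here means a stronger inhibitor, a higher number a weaker inhibitor), compound 1 gives 26000 nM, and compound 3 gives 33100 nM. The change between them, (vinyl in place of prop-1-en-1-yl on a carbonyl carbon), sits on a carbonyl carbon whose other neighbour is an amide-type nitrogen, and it made a 1.3-fold higher number from compound 1 to compound 3 (0.10 log units; within the scatter). In this assay compound 2 gives 27200 nM; its gaps to compound 1 and to compound 3 both lie within the scatter, so no order among the three compounds can be read from these numbers. Compound 4 `C=CC(=O)N1CCCC(n2nc(-c3ccc(Oc4ccccc4)cc3)cc2CO)C1` has not yet been measured. It differs from compound 2 by vinyl in place of prop-1-en-1-yl on a carbonyl carbon; here the carbonyl carbon's other neighbour is an amide-type nitrogen in a ring, so this is the same kind of change as that from compound 1 to compound 3, not the same change. Since the earlier step of a 1.3-fold higher number from compound 1 to compound 3 (0.10 log units; within the scatter) stayed within the scatter, the expected step in this assay is a 1.2-fold higher number from compound 2 to compound 4 (0.08 log units; within the scatter), set beside that measured one and resting on compound 1, compound 3 and compound 2 alone. On that basis compound 4 is estimated in this assay to give 33000 nM, with a likely range from 16000 nM to 70000 nM.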

Compound 4, half-maximal inhibitory concentration: 5400 nM
The estimate for compound 4 lay 6.1-fold (0.79 log units) above the measured number; the measured number lies below the stated range.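

On the core of compound 2, vinyl in place of prop-1-en-1-yl on a carbonyl carbon whose other neighbour is an amide-type nitrogen in a ring gave a 5.0-fold lower number from compound 2 to compound 4 (0.70 log units; beyond the scatter) in this assay. The same change therefore did not carry over from one core to the other with the same size: the same change on two cores in this assay, a 1.3-fold higher number (0.10 log units; within the scatter) from compound 1 to compound 3 and a 5.0-fold lower number (0.70 log units; beyond the scatter) from compound 2 to compound 4, 6.4-fold (0.81 log units) apart, beyond the scatter of two such steps. This shows that, among these four compounds, the result of the change depends on the core that bears it, but it does not show which difference between the cores goes with the gap, and with only one pair on each core it gives no rule for any further core.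

The compounds shown leave open whether the gap follows the amide-type nitrogen in a ring, the carboxylic acid on the core of compound 1 or some other part of the cores. They also leave open how an ethyl group, or a prop-1-en-1-yl chain ending in a dimethylamino group, would read on the same carbonyl carbon of either core.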